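Working notes: removing the bromo from compound 2

The source may hold more compounds than are shown below. What is called first, only, known or untested is meant among the compounds shown, and "the series" means these compounds.

Compound 1 `Cc1ccc(NC(=O)c2ccccc2OCCCCn2ccnc2)cc1Nc1nccc(-c2cccnc2)n1`: 83400 nM
Compound 2 `Cc1ccc(NC(=O)c2ccc(OCCCCn3ccnc3)c(Br)c2)cc1Nc1nccc(-c2cccnc2)n1`: 31800 nM

Both values come from a functional assay on K-562R cells (Homo sapiens) for cytotoxicity, read by XTT assay, with a stated time of 24 h; a higher number here means a weaker inhibitor, a lower number a stronger inhibitor. Compound 2 has the lower of the two numbers, and its gap to compound 1 lies beyond the scatter. The next compound is compound 3 `Cc1ccc(NC(=O)c2ccc(OCCCCn3ccnc3)cc2)cc1Nc1nccc(-c2cccnc2)n1`, which carries hydrogen in place of bromo on an aromatic carbon. Within the data shown here, no measured pair shows this change alone, so the expectation rests on little. A small rise in the number, not clearly beyond the scatter, is expected in this assay a 1.7-fold higher number from compound 2 to compound 3 (0.24 log units; within the scatter). The estimate for compound 3 is 55000 nM, with an expected range from 22000 nM to 130000 nM.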

Compound 3, half-maximal inhibitory concentration: 99400 nM
The estimate for compound 3 lay 1.8-fold (0.26 log units) below the measured number; measured number inside the range.
By their numbers in this assay, from the lowest: compound 2; then compounds 1 and 3 (each within the scatter of the next).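

In this assay, among these compounds, the bromo on the aromatic carbon ortho to a 4-(1H-imidazol-1-yl)butoxy group gives the first single-place reading: hydrogen in its place brings a 3.1-fold higher number from compound 2 to compound 3 (0.49 log units; beyond the scatter). This position therefore responds to the change, and the bromo goes with the lower number. Nothing on hand accounts for the step.

Going by these compounds, whether chloro or methyl on this carbon would hold the number of compound 2 remains open. So does the effect of a longer chain in place of the 4-(1H-imidazol-1-yl)butoxy group with the bromo kept.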